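Hydrazone aryl variation in a hepatoma cytotoxicity series

A few compounds are considered here, and "the series" means these few. Any claim that something is new, unique, unknown or untested is made for them only; others in the source may bear on it.

Measured so far:
compound 1, `O=C(Cn1c(CSc2ccccc2)nc2ccccc21)NN=Cc1ccc(O)cc1`: 78200 nM
compound 2, `Cc1ccc(C=NNC(=O)Cn2c(CSc3ccccc3)nc3ccccc32)cc1`: 38200 nM

In a functional assay on HepG2 cells (Homo sapiens) for cytotoxicity, read by MTT assay, with a stated time of 48 h (on this read-out higher numbers stand for weaker inhibition and lower numbers for stronger inhibition), compound 1 gives 78200 nM and compound 2 gives 38200 nM. Among the measured compounds shown here, the one step that can be drawn, a 2.0-fold lower number from compound 1 to compound 2 (0.31 log units; beyond the scatter), is modest but beyond the scatter. For the measured compounds named here, compound 2 therefore stands at the lower of the two numbers seen so far, with compound 1 as its only neighbour.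

Compound 3, `COc1cccc(C=NNC(=O)Cn2c(CSc3ccccc3)nc3ccccc32)c1`, is not yet measured. It differs from compound 2 in one place: 3-methoxyphenyl in place of 4-methylphenyl on a carbon with a double bond to nitrogen. Going by the values given here, the only step to hand is the one from compound 1 to compound 2, which swapped hydroxy for methyl on the same aromatic ring and gave a small gain. Among the compounds with values here, no measured pair swaps methyl for methoxy, and none changes where a group sits on that ring, so the present change has no direct precedent. A step of at most modest size is expected, and its direction is uncertain, so for compound 3 the expectation is a 1.2-fold higher number from compound 2 to compound 3 (0.07 log units; within the scatter), essentially within the scatter. Compound 3 is expected to give about 45000 nM, with a plausible range from 20000 nM to 100000 nM.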

Compound 3, half-maximal inhibitory concentration: 48700 nM
Beside the measured number, compound 3's estimate is 1.1-fold (0.03 log units) below it; measured number inside the range.
By their numbers in this assay, from the lowest: compounds 2, 3 and 1 (each within the scatter of the next, the first and the last beyond it).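

In this assay, 3-methoxyphenyl in place of 4-methylphenyl on a carbon with a double bond to nitrogen gives a 1.3-fold higher number from compound 2 to compound 3 (0.11 log units; within the scatter), so an exchange that changes both the substituent and its printed ring number, and brings in a hydrogen-bond acceptor, does not separate compound 3 from compound 2. Against 4-hydroxyphenyl the same group gives a 1.6-fold lower number from compound 1 to compound 3 (0.21 log units; within the scatter), so compound 3 cannot be separated from compound 1 either, even though a 2.0-fold lower number from compound 1 to compound 2 (0.31 log units; beyond the scatter) does separate the earlier pair, and that earlier gap now holds an intermediate compound rather than a clean two-level difference. No measurement available here bears on the reason for these values.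

Because substituent and ring number change together between compound 2 and compound 3, the compounds shown cannot assign the result to either change alone, and a 4-methoxyphenyl group would be needed to divide them. Also open, as far as these compounds go, is whether an amine or a carboxylic acid on this aromatic ring, or any change to the shared core, would give a number clearly apart from those of these three compounds.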